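Fluoro for Methoxy on the Aryl Ring of Compound 2

The compounds below may be only part of what the source reports. "The series", "measured", "known", "first", "only" and "open" are said of these compounds alone.

Compound 1, `CC1=CC[C@H](C(C)(C)N=C=S)CC1`, gives > 100000 nM in a functional assay on NCI-H460 cells (Homo sapiens) for inhibition, read by sulforhodamine B assay, with a stated time of 48 h (a higher number here means a weaker inhibitor of growth, a lower number a stronger inhibitor of growth), a limit of the assay rather than a number.
Compound 2, `COc1ccc(/C=N/NC(=S)NC(C)(C)[C@H]2CC=C(C)CC2)cc1`, gives 22500 nM in this assay.
Compound 3, `CC1=CC[C@H](C(C)(C)NC(=S)N/N=C/c2ccc(O)cc2)CC1`, gives > 100000 nM in this assay, again a limit and not a number.

Among the compounds with values here, compound 2 is thus the only compound of the three with a measured number; the other two sit at the limit of > 100000 nM in this assay, at which 2 of the 3 values shown sit. Within the data shown here, the one step measured on the aromatic ring, an at least 4.4-fold higher number from compound 2 to compound 3 (0.64 log units; beyond the scatter), shows that replacing the methyl of the methoxy group with hydrogen costs activity beyond the scatter.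

Compound 4, `CC1=CC[C@H](C(C)(C)NC(=S)N/N=C/c2ccc(F)cc2)CC1`, carries the change (fluoro in place of methoxy on an aromatic carbon). This is fluoro in place of methoxy on an aromatic carbon, a change not covered by any measured pair. Among the measured compounds shown here, the only guide is the step from compound 2 to compound 3, where loss of the methoxy's methyl weakened growth inhibition by at least a modest amount. For the measured compounds named here, removing the whole methoxy for fluoro is a different change, so the direction is uncertain, but the sole measured evidence points toward weaker inhibition. The expected step is a 1.8-fold higher number from compound 2 to compound 4 (0.25 log units; within the scatter). Compound 4 is therefore estimated to give about 40000 nM in this assay, with a range from 12000 nM to 100000 nM.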

Compound 4, concentration for 50% growth inhibition: > 100000 nM
Compound 4: a limit, no number; the forecaster's own chance of this, stated with the estimate: 35%; at least 2.5-fold (0.39 log units) between middle value and limit.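

In this assay, the change from methoxy to fluoro, on an aromatic carbon para to a large group, gives an at least 4.4-fold higher number from compound 2 to compound 4 (0.64 log units; beyond the scatter). Within the data shown here, the earlier compounds showed only that removing the methyl from the methoxy costs activity, whereas this step shows that a group with no oxygen at this place also fails to keep the activity of compound 2, so that methoxy is the only one of the three groups here with a measured number. Compound 3 and compound 4 both stand at limits, so the step between them cannot be read, and compound 2 remains the only compound with a number: the limit of > 100000 nM in this assay, at which 3 of the 4 values shown sit.

Going by these compounds, how far compound 3 and compound 4 lie from compound 2 therefore stays open, as does any order between hydroxy and fluoro at this place. Also open, on these data alone, is whether a different group here, such as ethoxy, a dimethylamino group or a chlorine atom, would match or better the number of compound 2, which would show whether the activity depends on methoxy itself.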